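A Ring Swap on the Core and Liver Stability

A few compounds are considered here, and "the series" means these few. Any claim that something is new, unique, unknown or untested is made for them only; others in the source may bear on it.

Compound 2, with structure `CCC1C(=O)N(C)c2cnc(-n3ccnc3-c3ccc(F)cc3)nc2N1C1CCC(F)(F)C1`, stands lowest of the two compounds measured in an ADME assay on microsomes from liver (Homo sapiens) for metabolic stability, with a stated time of 30 min, tested at 1 uM; on this read-out lower numbers stand for a less stable compound and higher numbers for a more stable compound: compound 2 gives 6%. Compound 1, `CC[C@@H]1C(=O)N(C)c2cnc(-n3ccnc3-c3ccccc3)nc2N1[C@H]1CCOC1`, gives 17% in this assay, a gap beyond the usual scatter. Compound 3, `CCC1C(=O)N(C)c2cnc(-n3ccnc3-c3ccc(F)cc3)nc2N1c1ccc(F)cc1`, differs from compound 2 in one place: 4-fluorophenyl in place of 3,3-difluorocyclopentyl on a nitrogen on an aromatic ring in a ring. For the measured compounds named here, no measured pair shows this exchange, so its effect is unknown. For compound 3 the expected step of a number 4 percentage points higher from compound 2 to compound 3 (within the scatter) is small, not clearly beyond the scatter in either direction. Compound 3 is therefore estimated at 10%, within a range of 3% to 25%.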

Compound 3, percent of the compound remaining in the Homo sapiens assay: 47%
Beside the measured number, compound 3's estimate is 37 percentage points below it; measured number above the stated range.
By their numbers in the Homo sapiens assay, from the lowest: compound 2; then compound 1; then compound 3.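

Putting the aromatic ring in place of the non-aromatic one on this nitrogen moves the Homo sapiens assay by a large step, a number 41 percentage points higher from compound 2 to compound 3 (beyond the scatter), so the group at this position can strongly shape the result. In a physicochemical assay for lipophilicity (on this read-out lower numbers stand for lower lipophilicity and higher numbers for higher lipophilicity), compound 2 gives 3.1 and compound 3 gives 3.4, two values within the scatter of each other. Nothing measured here gives a reason for the large step. On these data alone, whether a pyridyl ring at this position would give a similar result remains open, as does the part played by the fluorine on the 4-fluorophenyl group.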